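The compounds below may be only part of what the source reports. "The series", "measured", "known", "first", "only" and "open" are said of these compounds alone.

Measured compounds, with the activity read-out in a functional assay on the whole organism (strain NMRI) with Mus musculus as the target, with a stated time of 60 min, at a dose of 20 mg/kg by the intraperitoneal route; a higher number here means a stronger effect of the compound at the dose given, a lower number a weaker effect:

compound 1, `CCSc1nnc(Cc2ccc(Cl)cc2Oc2ccccc2Cl)[nH]1`, gives 174%
compound 2, `CCCSc1nnc(Cc2ccc(Cl)cc2Oc2ccccc2Cl)[nH]1`, gives 134%
compound 3, `CCSc1nnc(Cc2ccc(Cl)cc2Oc2ccccc2F)[nH]1`, gives 141%

Compound 2 differs from compound 1 by methyl in place of hydrogen on a saturated chain carbon, two bonds along the chain from a sulfur; the step is a number 40 percentage points lower from compound 1 to compound 2 (beyond the scatter). Compound 3 differs from compound 1 in the core, by fluoro in place of chloro on an aromatic carbon, with the step of a number 33 percentage points lower from compound 1 to compound 3 (beyond the scatter). The values of compound 2 and compound 3 lie within the scatter of each other.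

Compound 4, `CCCSc1nnc(Cc2ccc(Cl)cc2Oc2ccccc2F)[nH]1`, is not yet measured in this assay. It differs from compound 3 by methyl in place of hydrogen on a saturated chain carbon, two bonds along the chain from a sulfur; the place is worded identically to the change from compound 1 to compound 2, so this is the same change, now made on the core of compound 3. Within the data shown here, only the one earlier instance exists to go by. The step is expected to be a number 38 percentage points lower from compound 3 to compound 4 (beyond the scatter), resting on compound 1 and compound 2 because a number 40 percentage points lower from compound 1 to compound 2 (beyond the scatter). Compound 4 is therefore estimated at 103%, between 72% and 135%.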

Compound 4, a percentage reported as activity, at one dose (the size of the read-out at that dose, not a potency): 133%
Compound 4: middle estimate off by 30 percentage points, on the low side; measured number inside the range.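

On the core of compound 3, the change to propylsulfanyl gives a number 8 percentage points lower from compound 3 to compound 4 (within the scatter), so in this assay its size does not carry over from the core of compound 1: the same change on two cores in this assay, a number 40 percentage points lower (beyond the scatter) from compound 1 to compound 2 and a number 8 percentage points lower (within the scatter) from compound 3 to compound 4, 32 percentage points apart, beyond the scatter of two such steps

Fluoro in place of chloro likewise gives a number 1 percentage points lower from compound 2 to compound 4 (within the scatter) on the propylsulfanyl compounds, so its size also depends on the core: the same change on two cores in this assay, a number 33 percentage points lower (beyond the scatter) from compound 1 to compound 3 and a number 1 percentage points lower (within the scatter) from compound 2 to compound 4, 32 percentage points apart, beyond the scatter of two such steps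

Both comparisons rest on the same four compounds and describe one interaction between the two changes; they show neither its cause nor whether it extends beyond these compounds.

Going by these compounds, it remains open whether the pairing of ethylsulfanyl with chloro in compound 1 stands alone. The compounds shown also leave open how a butylsulfanyl chain, or bromo in place of chloro or fluoro, would behave.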